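A few compounds are considered here, and "the series" means these few. Any claim that something is new, unique, unknown or untested is made for them only; others in the source may bear on it.

In a functional assay on the whole organism (strain Swiss) with Mus musculus as the target, in the maximal electroshock model, with a stated time of 1 h, at a dose of 100 mg/kg by the intraperitoneal route (a higher number here means a stronger effect of the compound at the dose given, a lower number a weaker effect), the three measured compounds gave these results:

compound 1 `CCC(C(=O)N1CCN(c2cccc(C)c2)CC1)N1C(=O)CCC1=O`: 0%
compound 2 `CCC(C(=O)N1CCN(c2cccc(Cl)c2)CC1)N1C(=O)CCC1=O`: 0%
compound 3 `Cc1cccc(N2CCN(C(=O)C(C)N3C(=O)CCC3=O)CC2)c1`: 0%

Compound 1 and compound 2 differ by chloro in place of methyl on an aromatic carbon, and that change gave no change at the digits printed from compound 1 to compound 2 (within the scatter). The cores of compound 1 and compound 3 differ by hydrogen in place of methyl on a saturated chain carbon, two bonds along the chain from an amide-type nitrogen in a ring and a carbonyl carbon, which gave no change at the digits printed from compound 1 to compound 3 (within the scatter).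

Compound 4 `CC(C(=O)N1CCN(c2cccc(Cl)c2)CC1)N1C(=O)CCC1=O` is not yet measured. It differs from compound 3 by chloro in place of methyl on an aromatic carbon, the same change that was made from compound 1 to compound 2, at the same place.

For compound 4 the expected step in this assay is no change at the digits printed from compound 3 to compound 4 (within the scatter), and this expectation rests on compound 1 and compound 2, where the same change gave no change at the digits printed from compound 1 to compound 2 (within the scatter). Compound 4 is therefore estimated at 0%, with a range from 0% to 10%.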

Compound 4, a percentage reported as activity, at one dose (the size of the read-out at that dose, not a potency): 50%
Compound 4: the middle estimate sits 50 percentage points below what was measured, and the stated range ends below it.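

In this assay, chloro in place of methyl on the aromatic carbon gave a number 50 percentage points higher from compound 3 to compound 4 (beyond the scatter), so this change does not carry over unchanged from one core to another: the same change on two cores in this assay, no change at the digits printed (within the scatter) from compound 1 to compound 2 and a number 50 percentage points higher (beyond the scatter) from compound 3 to compound 4, 50 percentage points apart, beyond the scatter of two such steps
The change on the saturated chain carbon gave a number 50 percentage points higher from compound 2 to compound 4 (beyond the scatter), and it too depends on the rest of the molecule: the same change on two cores in this assay, no change at the digits printed (within the scatter) from compound 1 to compound 3 and a number 50 percentage points higher (beyond the scatter) from compound 2 to compound 4, 50 percentage points apart, beyond the scatter of two such steps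
For the compounds shown here, this shows that the two changes count only in combination here, with compound 4 the sole compound reading above the others, but it does not show why, and one such combination gives no rule for other cores.

Open, as far as these compounds go, is whether bromo or methoxy on the aromatic carbon would match chloro. Also open, from the compounds shown here alone, is how a propyl group on the saturated chain carbon would read.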